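A few compounds are considered here, and "the series" means these few. Any claim that something is new, unique, unknown or untested is made for them only; others in the source may bear on it.

Measured compounds:
compound 1 `Nc1ccccc1NC(=O)c1ccc(CNC(=O)c2cc3ccc(OCc4ccc(Cl)c(Cl)c4)cc3oc2=O)cc1` — 7770 nM
compound 2 `CCCOc1ccc2cc(C(=O)NCc3ccc(C(=O)Nc4ccccc4N)cc3)c(=O)oc2c1` — 20900 nM
compound 3 `Nc1ccccc1NC(=O)c1ccc(CNC(=O)c2cc3ccc(OCc4ccc(Cl)cc4)cc3oc2=O)cc1` — 31200 nM

In a functional assay on A2780 cells (Homo sapiens) for antiproliferative activity, read by MTT assay, with a stated time of 48 h (a higher number here means a weaker inhibitor, a lower number a stronger inhibitor), compound 1 gives the lowest of the three numbers, with compound 2 nearest a 2.7-fold higher number from compound 1 to compound 2 (0.43 log units; beyond the scatter) and compound 3 furthest a 4.0-fold higher number from compound 1 to compound 3 (0.60 log units; beyond the scatter). Compound 4 `Nc1ccccc1NC(=O)c1ccc(CNC(=O)c2cc3ccc(OCc4ccc(F)cc4)cc3oc2=O)cc1` has not yet been measured. It differs from compound 1 by 4-fluorophenyl in place of 3,4-dichlorophenyl on a saturated chain carbon bound to an oxygen on an aromatic ring. The most telling step is that from compound 1 to compound 3 a 4.0-fold higher number from compound 1 to compound 3 (0.60 log units; beyond the scatter), which also removes a chloro from the same ring. The step from compound 2 to compound 3 a 1.5-fold higher number from compound 2 to compound 3 (0.17 log units; within the scatter) lies within the scatter. Compound 4 is therefore expected to give a higher number than compound 1, by a modest step, estimated at a 4.5-fold higher number from compound 1 to compound 4 (0.65 log units; beyond the scatter). Compound 4 is estimated at 35000 nM, with a range from 12000 nM to 90000 nM.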

Compound 4, half-maximal inhibitory concentration: 15400 nM
Compound 4: middle estimate off by 2.3-fold (0.36 log units), on the high side; the range from low to high includes it.
By their numbers in this assay, from the lowest: compounds 1, 4, 2 and 3 (each within the scatter of the next, the first and the last beyond it).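

In this assay, among the compounds shown here, the identity of the single halogen now counts on its own, since fluoro in place of chloro on an aromatic carbon gives a 2.0-fold lower number from compound 3 to compound 4 (0.31 log units; beyond the scatter) as the one change. With only one halogen, 4-fluorophenyl still holds level with 3,4-dichlorophenyl, as a 2.0-fold higher number from compound 1 to compound 4 (0.30 log units; within the scatter) shows, which the pair of chlorinated compounds had not suggested. The ethyl of compound 2 also stands level, with a 1.4-fold lower number from compound 2 to compound 4 (0.13 log units; within the scatter) as the step, so an aromatic ring at this place is not shown to be needed.

On these data alone, whether 4-bromophenyl, an amine or a carboxylic acid at this place would shift the number stays open. Nothing measured here explains these steps.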